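The source may report more compounds than this note shows. Statements on the series, on what has been measured and on what is new or still open speak of the compounds shown alone.

Compound 3, `CN(C)CCn1cnnc1-c1cc(Oc2ccc(NC(=O)N/N=C/c3c[nH]c4ccccc34)cc2F)ccn1`, was tested in a functional assay on HT-29 cells (Homo sapiens) for cytotoxicity, read by MTT assay, with a stated time of 72 h (on this read-out lower numbers stand for stronger inhibition and higher numbers for weaker inhibition), and gave 1300 nM. Among the three measured compounds it stands second highest: compound 1, `COc1ccc(OC)c(/C=N/NC(=O)Nc2ccc(Oc3ccnc(-c4nncn4CCN(C)C)c3)c(F)c2)c1`, gives 2070 nM and lies within the scatter of compound 3, whereas compound 2, `CN(C)CCn1cnnc1-c1cc(Oc2ccc(NC(=O)N/N=C/c3ccc(F)cc3Cl)cc2F)ccn1`, gives 510 nM, a step of a 2.5-fold higher number from compound 2 to compound 3 (0.41 log units; beyond the scatter). Compound 4, `COc1ccc(/C=N/NC(=O)Nc2ccc(Oc3ccnc(-c4nncn4CCN(C)C)c3)c(F)c2)cc1O`, differs from compound 3 in one place: 3-hydroxy-4-methoxyphenyl in place of 1H-indol-3-yl on a carbon with a double bond to nitrogen. The step that bears most on this change is a 1.6-fold lower number from compound 1 to compound 3 (0.20 log units; within the scatter), since the group in compound 1 also carries two oxygen atoms on a phenyl ring; that step was within the scatter, while a 4.1-fold lower number from compound 1 to compound 2 (0.61 log units; beyond the scatter) was modest. Compound 4 is therefore expected to show a step of a 1.2-fold higher number from compound 3 to compound 4 (0.06 log units; within the scatter), with a half-maximal inhibitory concentration estimated near 1500 nM, between 600 nM and 4000 nM.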

Compound 4, half-maximal inhibitory concentration: 960 nM
Beside the measured number, compound 4's estimate is 1.6-fold (0.19 log units) above it, and the stated range covers the measured number.
By their numbers in this assay, from the lowest: compounds 2, 4, 3 and 1 (each within the scatter of the next, the first and the last beyond it).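

The steps of a 1.4-fold lower number from compound 3 to compound 4 (0.13 log units; within the scatter) and a 1.9-fold higher number from compound 2 to compound 4 (0.27 log units; within the scatter) leave 3-hydroxy-4-methoxyphenyl on this carbon indistinguishable from both 1H-indol-3-yl and 2-chloro-4-fluorophenyl. The step of a 2.2-fold lower number from compound 1 to compound 4 (0.33 log units; beyond the scatter) is modest but separates two phenyl groups that both carry oxygen, so oxygen on the ring does not by itself set the number here. No measurement given explains this difference. The compounds shown leave open whether an amine or a carboxylic acid on the phenyl ring would change the number at this position.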